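A few compounds are considered here, and "the series" means these few. Any claim that something is new, unique, unknown or untested is made for them only; others in the source may bear on it.

Working notes on the series

The three measured compounds share one core. Compound 1 `COc1ccc(N2CCN(Cc3csc(N)c3C(=O)c3ccc(Cl)cc3)CC2)cc1` is measured in a functional assay on CHO cells with adenosine receptor A1 (Homo sapiens) as the target, read by cAMP accumulation and immunoassay, with a stated time of 6 min, tested at 0.01 uM (on this read-out higher numbers stand for a weaker effect at the one concentration tested and lower numbers for a stronger effect), where compound 1 gives -1.2%. Compound 2 `Nc1scc(CN2CCC(c3ccc(Cl)cc3)CC2)c1C(=O)c1ccc(Cl)cc1` gives 0% in this assay, and compound 3 `Nc1scc(CN2CCN(c3c(F)cccc3F)CC2)c1C(=O)c1cccc(C(F)(F)F)c1` gives 2.1%. The gap from compound 1 to compound 2 and the gap from compound 1 to compound 3 both lie within the usual scatter, so the three values cannot be told apart; compound 1 stands with the others in a flat band of near-zero activity at the tested concentration.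

Compound 4 `Nc1scc(CN2CCN(c3ccccc3F)CC2)c1C(=O)c1ccc(Cl)cc1` is not yet measured in this assay. Its difference from compound 1 is 2-fluorophenyl in place of 4-methoxyphenyl on an amine nitrogen in a ring. Among the measured compounds shown here, no step between measured compounds is available for this change, so the expectation rests on the flat band alone: the step from compound 1 to compound 4 in this assay is expected to stay within the scatter, a number 1.7 percentage points higher from compound 1 to compound 4 (within the scatter), in no fixed direction. Compound 4 is therefore estimated at 0.5% in this assay, with a range from -8% to 10%.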

Compound 4, a percentage reported as activity, at one concentration (the size of the read-out at that concentration, not a potency): 2.1%
The estimate for compound 4 lay 1.6 percentage points below the measured number; low and high end bracket the measured number.
By their numbers in this assay, from the lowest: compounds 1, 2, 3 and 4 (each within the scatter of the next).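

The first step available at this position, on an amine nitrogen in a ring, gives in this assay a number 3.3 percentage points higher from compound 1 to compound 4 (within the scatter) and so 2-fluorophenyl in place of 4-methoxyphenyl does not separate the two compounds. The exchange takes away the hydrogen-bond acceptor of the group that leaves and brings in fluorine, yet the pair stays in the same flat band near zero at the one concentration tested. No measurement at hand bears on a reason for this result.

With all four values in that band, the series shows no range in which a change of aryl group could register. From the compounds shown here alone, whether an amine, a carboxylic acid or a longer chain in place of the aryl group on this ring nitrogen would lift a compound out of the band stays open.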